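Chloro for trifluoromethyl on a piperazine aryl group

A few compounds are considered here, and "the series" means these few. Any claim that something is new, unique, unknown or untested is made for them only; others in the source may bear on it.

Measured compounds:
- compound 1, `CCCc1nc(-c2ccccc2)c(CNCCCN2CCN(c3ccc(C(F)(F)F)cc3)CC2)o1`: 7250 nM
- compound 2, `CCCc1nc(-c2ccccc2)c(CNCCN2CCN(c3cccc(Cl)c3)CC2)o1`: 1450 nM

The two compounds were tested in an assay on HEK293 cells for inhibition of Voltage-dependent T-type calcium channel subunit alpha-1G (Homo sapiens), read by patch clamp; a lower number here means a stronger inhibitor, a higher number a weaker inhibitor. Compound 1 gives 7250 nM, the highest of the two numbers. Compound 2 gives 1450 nM, a lower number, and the gap between the two lies beyond the scatter; the two compounds differ in more than one place, so what share of the gap belongs to each difference cannot be read from these two values alone.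

Compound 3, `CCCc1nc(-c2ccccc2)c(CNCCCN2CCN(c3ccc(Cl)cc3)CC2)o1`, has not yet been measured in this assay. It differs from compound 1 by chloro in place of trifluoromethyl on an aromatic carbon, para to a large group. Going by the values given here, no measured pair shows this change by itself. With compound 2 carrying a chloro group and giving 1450 nM, a step from compound 1 to compound 3 toward a somewhat lower number is expected, of about a 1.8-fold lower number from compound 1 to compound 3 (0.26 log units; within the scatter), though a change within the scatter is also plausible. For compound 3 the estimate in this assay is 4000 nM, with a range from 1500 nM to 12000 nM.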

Compound 3, half-maximal inhibitory concentration: 1310 nM
The estimate for compound 3 lay 3.1-fold (0.48 log units) above the measured number; the whole stated range lies above it.
By their numbers in this assay, from the lowest: compounds 3 and 2 (each within the scatter of the next); then compound 1.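

Within this assay the change from 4-(trifluoromethyl)phenyl to 4-chlorophenyl, with the rest of the molecule unchanged, gives a 5.5-fold lower number from compound 1 to compound 3 (0.74 log units; beyond the scatter) and so stands beyond the scatter. Compound 1 and compound 2 differ in more than one place, so their gap could not be divided among those differences, whereas this pair isolates a single change on an aromatic carbon, para to a large group, and shows that this change alone is enough to move the number clearly. Trifluoromethyl and chloro both count no hydrogen-bond donors, no hydrogen-bond acceptors and no net charge, so a step of this size appears here with those counts unchanged, although one group of four heavy atoms gives way to a single chlorine.

As far as these compounds go, whether the step carries over to the chain of compound 2 remains open, as does what a fluoro group, a methoxy group or a nitrile would give at this same place on the ring. This single pair offers no measured evidence to explain the step, and nothing else available here accounts for it.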